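Lengthening the ester chain on a shared core

A few compounds are considered here, and "the series" means these few. Any claim that something is new, unique, unknown or untested is made for them only; others in the source may bear on it.

Compound 1 `CC(C)COC(=O)NS(=O)(=O)Nc1cccc(-c2cc3ccccc3[nH]2)c1` gives 30000 nM in an assay for inhibition of Polyunsaturated fatty acid lipoxygenase ALOX15 (Oryctolagus cuniculus), read by spectrophotometry; a lower number here means a stronger inhibitor, a higher number a weaker inhibitor. Compound 2 `C=CCOC(=O)NS(=O)(=O)Nc1cccc(-c2cc3ccccc3[nH]2)c1` gives 15400 nM.

Among the measured compounds shown here, compound 2 has the lower of the two numbers, but the only measured step, a 1.9-fold lower number from compound 1 to compound 2 (0.29 log units; within the scatter), sits within the scatter, so the two compounds cannot be ranked. Compound 3 `CCCCCCCCOC(=O)NS(=O)(=O)Nc1cccc(-c2cc3ccccc3[nH]2)c1` differs from compound 2 by heptyl in place of vinyl on a saturated chain carbon bound to an oxygen next to a carbonyl group. That single step swaps one short group for another and says little about a long straight chain, so no clear direction is expected. For compound 3 the estimate is 20000 nM, with a range from 5000 nM to 80000 nM, which means an expected step of a 1.3-fold higher number from compound 2 to compound 3 (0.11 log units; within the scatter).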

Compound 3, half-maximal inhibitory concentration: 1550 nM
Beside the measured number, compound 3's estimate is 13-fold (1.11 log units) above it; the whole stated range lies above it.
By their numbers in this assay, from the lowest: compound 3; then compounds 2 and 1 (each within the scatter of the next).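

The position on a saturated chain carbon bound to an oxygen next to a carbonyl group can clearly move the number in this assay once a long chain is present. Heptyl in place of vinyl gives a clear change (a 9.9-fold lower number from compound 2 to compound 3 (1.00 log units; beyond the scatter)), and heptyl in place of isopropyl gives a larger one (a 19-fold lower number from compound 1 to compound 3 (1.29 log units; beyond the scatter)), whereas the swap between the two short groups stayed within the scatter. Nothing available explains this gain.

As far as these compounds go, only one long chain appears here, so it remains open whether a longer chain such as dodecyl would lower the number further. From the compounds shown here alone, whether a chain ending in an amine or a carboxylic acid would keep the gain is also open.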